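This account rests on a few compounds, and the source may have more. Where it says the series, first, only, none or still open, it means among the compounds named here.

For the measured compounds named here, in a functional assay (aorta) for inhibition, with Rattus norvegicus as the target (a higher number here means a weaker inhibitor, a lower number a stronger inhibitor), compound 1 (`CC/N=C(\S)[C@]1(c2cccnc2)CCCC[S+]1[O-]`) gives 300 nM as the only reading that is not a limit. Compound 2 (`N/N=C(\S)[C@]1(c2cccnc2)CCCC[S+]1[O-]`) reports > 30000 nM as a limit. Compound 3 (`[O-][S+]1CCCC[C@]1(CO)c1cccnc1`) likewise reports > 30000 nM as a limit; that is the limit of > 30000 nM in this assay, at which 2 of the 3 values shown sit, and no firmer place can be given. Compound 4 (`CNC(=O)[C@]1(c2cccnc2)CCCC[S+]1[O-]`) carries methylcarbamoyl in place of hydroxymethyl on a saturated ring carbon. Two large steps bear on this, an at least 100-fold higher number from compound 1 to compound 3 (2.00 log units; beyond the scatter) and an at least 100-fold higher number from compound 1 to compound 2 (2.00 log units; beyond the scatter) as well, whereas a step that the two limits leave unreadable from compound 2 to compound 3 is unreadable. Compound 4 lacks the group of compound 1, so in this assay only a modest move to a lower number is expected, and another limit is quite possible. The expected change is an at least 3.0-fold lower number from compound 3 to compound 4 (0.47 log units; beyond the scatter) on this reasoning. Compound 4 is estimated at 10000 nM with 2000 nM to 50000 nM as its range.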

Compound 4, concentration for 90% inhibition: > 30000 nM
Compound 4 was reported as a limit (the forecaster's own chance of this, stated with the estimate: 55%); at least 3.0-fold (0.47 log units) between middle value and limit.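

In this assay, compound 4 is reported only as a limit, > 30000 nM. On the saturated ring carbon, methylcarbamoyl therefore does not recover the reading of the core of compound 1, an at least 100-fold higher number from compound 1 to compound 4 (2.00 log units; beyond the scatter), so a nitrogen-bearing group at this position is not enough by itself. The steps among the limit compounds cannot be read, and the series now gathers at one ceiling: the limit of > 30000 nM in this assay, at which 3 of the 4 values shown sit.

Still open, going by these compounds, is whether the loss follows the change from sulfur to oxygen or the shorter chain on nitrogen. Ethylcarbamoyl and methylthiocarbamoyl would separate these two changes.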